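A few compounds are considered here, and "the series" means these few. Any claim that something is new, unique, unknown or untested is made for them only; others in the source may bear on it.

Measured so far:
- compound 1 `Cc1cccc(/C(N)=N/NC(=S)N2CCCCC2)n1` — 12400 nM in a functional assay on A-431 cells (Homo sapiens) for cytotoxicity, read by MTT assay, with a stated time of 72 h; a higher number here means a weaker inhibitor, a lower number a stronger inhibitor
- compound 2 `N/C(=N\NC(=S)N1CCOCC1)c1ccccn1` — 4800 nM
- compound 3 `Cc1ccnc(/C(N)=N/NC(=S)N2CCCCC2)c1` — 18900 nM

Compound 3 gives the highest of the three numbers in this assay. Its nearest neighbour is compound 1, whose number is lower but within the scatter; compound 2 lies furthest, with a lower number beyond the scatter.

The next compound, compound 4 `N/C(=N\NC(=S)N1CCCCC1)c1ccccn1`, differs from compound 3 by hydrogen in place of methyl on an aromatic carbon. Within the data shown here, no step between measured compounds isolates this change, so the expectation rests on the spread of the three numbers. The step from compound 3 to compound 4 is expected to run toward a lower number, at the edge of the scatter, as a 2.4-fold lower number from compound 3 to compound 4 (0.37 log units; beyond the scatter). For compound 4 the estimate in this assay is 8000 nM, within 3000 nM to 22000 nM.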

Compound 4, half-maximal inhibitory concentration: 6900 nM
Estimate against measurement, compound 4: 1.2-fold (0.06 log units) above, and the stated range covers the measured number.
By their numbers in this assay, from the lowest: compounds 2, 4, 1 and 3 (each within the scatter of the next, the first and the last beyond it).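

Hydrogen in place of methyl on an aromatic carbon opposite the ring nitrogen gives a 2.7-fold lower number from compound 3 to compound 4 (0.44 log units; beyond the scatter) in this assay as a modest step, so this methyl can be exchanged with a readable change in the number. The methyl of compound 1 gives no such reading, with a 1.8-fold lower number from compound 1 to compound 4 (0.25 log units; within the scatter) and piperidin-1-yl in place of morpholin-4-yl on a thiocarbonyl carbon likewise gives only a 1.4-fold higher number from compound 2 to compound 4 (0.16 log units; within the scatter) as its step. No measurement on hand accounts for these steps. From the compounds shown here alone, whether a chlorine, a methoxy group or an amine at this ring carbon would move the number remains open, as does a dimethylamino group on the thiocarbonyl carbon.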